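The source may hold more compounds than are shown below. What is called first, only, known or untested is meant among the compounds shown, and "the series" means these compounds.

Working notes on the series. Compound 1 `CC1CCC(=NNc2ccccc2C(=O)O)c2ncc(C(=O)O)c(=O)n21` is one of three measured members; in a functional assay on the whole organism with Rattus norvegicus as the target (on this read-out higher numbers stand for an effect only at larger amounts of compound and lower numbers for an effect already at smaller amounts), compound 1 gives 0.48 umol/kg. Compound 2 `CC1CCC(=NNc2ccc(Cl)c(Cl)c2)c2ncc(C(=O)O)c(=O)n21` in this assay gives 0.89 umol/kg, and this value and that of compound 1 lie within the scatter of each other, so no order between the two is read. Compound 3 `Cc1nc2n(c(=O)c1C(=O)O)C(C)CCC2=NNc1ccccc1` in this assay reaches only a limit, > 100 umol/kg, not a number; this matches (the limit of > 100 umol/kg in this assay, at which 1 of the 3 values shown sits).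

Compound 4 `CNN=C1CCC(C)n2c1ncc(C(=O)O)c2=O` is not yet measured. It differs from compound 2 as follows: methyl in place of 3,4-dichlorophenyl on an amine nitrogen. For the measured compounds named here, no measured pair differs in only one place, so the size of this step has no direct precedent among the measured compounds. A step towards higher numbers in this assay is nevertheless expected, beyond the scatter, since the change removes the whole aromatic group that compounds 1 and 2 carry at this position. For compound 4 the value in this assay is estimated at 12 umol/kg, in a range from 2 umol/kg to 70 umol/kg. The step this implies is the expected 13-fold higher number from compound 2 to compound 4 (1.13 log units; beyond the scatter).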

Compound 4, dose for 50% inhibition: 17.5 umol/kg
The estimate for compound 4 lay 1.5-fold (0.16 log units) below the measured number, within the range that was stated.
By their numbers in this assay, from the lowest: compounds 1 and 2 (each within the scatter of the next); then compound 4. At a limit, above all of these: compound 3.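

For the compounds shown here, this is the first change that can be read in one place: in this assay, methyl in place of 3,4-dichlorophenyl on the amine nitrogen gives a 20-fold higher number from compound 2 to compound 4 (1.29 log units; beyond the scatter) as a large step. The group at this position therefore counts for the read-out, and the shared core does not by itself hold the low number of compound 2. Compound 4 still gives a measured number and not a limit, so an effect remains without the 3,4-dichlorophenyl group, though only at larger amounts of compound.

On these data alone, whether the step belongs to the aromatic ring or to its chlorines stays open, and a benzyl, cyclohexyl or butyl group on this nitrogen would speak to that. Nothing shown gives a cause for the step.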